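The source may hold more compounds than are shown below. What is called first, only, known or untested is meant among the compounds shown, and "the series" means these compounds.

Measured compounds:
- compound 1, `CCOC(=O)c1c(C)oc2ncnc(Nc3ccc(OCc4cccc(F)c4)c(Cl)c3)c12`: 257000 nM
- compound 2, `C#Cc1cccc(Nc2ncnc3oc(C)c(C(=O)OCC)c23)c1`: a limit only
- compound 3, `Cc1oc2ncnc(Nc3cccc(Br)c3)c2c1C(=O)NCCO`: 22000 nM

In a functional assay on MCF7 cells (Homo sapiens) for cytotoxicity, read by MTT assay, with a stated time of 72 h (a higher number here means a weaker inhibitor, a lower number a stronger inhibitor), compound 2 reports only a limit, > 1000000 nM, and so gives no number of its own. It stands at the limit of > 1000000 nM in this assay, at which 1 of the 3 values shown sits, the weak end of everything shown here. Compound 1 shares the ethyl ester and the core of compound 2 but carries a different aniline, and in this assay compound 1 gives 257000 nM. Compound 3, with an amide in place of the ester and a bromophenyl aniline, gives 22000 nM in this assay. No pair among these three differs in only one place, so no measured step can be read from them.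

Compound 4, `CCOC(=O)c1c(C)oc2ncnc(Nc3cccc(C)c3)c12`, is compound 2 with one change: methyl in place of ethynyl on an aromatic carbon. Both groups are small and uncharged, and the rest of the molecule is untouched. For the measured compounds named here, with no comparable measured step to lean on, the expected step from compound 2 to compound 4 is small, an at least 1.6-fold lower number from compound 2 to compound 4 (0.22 log units; that floor lies within the scatter), and may well stay within the scatter. Compound 4 is thus estimated at 600000 nM in this assay, within a range of 150000 nM to 2000000 nM, with a real chance that only a limit is returned again.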

Compound 4, half-maximal inhibitory concentration: > 1000000 nM
Compound 4: no number, only a limit (the forecaster's own chance of this, stated with the estimate: 45%); middle value at least 1.6-fold (0.22 log units) away from the limit.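

Compound 2 and compound 4 each return only a limit in this assay, and no step between them can be read: the limit of > 1000000 nM in this assay, at which 2 of the 4 values shown sit.

The compounds shown leave open whether methyl in place of ethynyl on an aromatic carbon changes the result in this assay at all, and by how much.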